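Trading a Protected Amine for a Hydroxyl Group

A few compounds are considered here, and "the series" means these few. Any claim that something is new, unique, unknown or untested is made for them only; others in the source may bear on it.

Of the compounds shown here, two have been tested in an assay on HEK293 cells for displacement of a labelled ligand from NPC1-like intracellular cholesterol transporter 1 (Homo sapiens); a lower number here means a stronger inhibitor, a higher number a weaker inhibitor. Compound 1 `CC(C)(C)c1ccc(C(=O)N2CCC3(CC2)C(=O)N(CC(=O)NCN)CN3c2ccccc2)cc1` gives 26500 nM, while compound 2 `CC(C)(C)OC(=O)NCC1CCCN(C(=O)CN2CN(c3ccccc3)C3(CCN(C(=O)c4ccc(C(C)(C)C)cc4)CC3)C2=O)C1` gives 9500 nM, the lower of the two numbers and beyond the scatter from compound 1. Compound 3 `CC(C)(C)c1ccc(C(=O)N2CCC3(CC2)C(=O)N(CC(=O)N2CCCC(CO)C2)CN3c2ccccc2)cc1` keeps the shared core and differs from compound 2 only in one place: hydroxy in place of (tert-butoxycarbonyl)amino on a saturated chain carbon bound to a saturated ring carbon. Going by the values given here, no measured pair shows this change, so its effect is open. The step of a 1.3-fold higher number from compound 2 to compound 3 (0.10 log units; within the scatter) is expected to stay within the scatter, in no clear direction. Compound 3 is estimated at 12000 nM, with a range from 4000 nM to 40000 nM.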

Compound 3, half-maximal inhibitory concentration: 8200 nM
Compound 3: the middle estimate sits 1.5-fold (0.17 log units) above what was measured; measured number inside the range.
By their numbers in this assay, from the lowest: compounds 3 and 2 (each within the scatter of the next); then compound 1.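

At this position the (tert-butoxycarbonyl)amino group, with 8 heavy atoms, can give way to hydroxy, with 1, and the outcome is a 1.2-fold lower number from compound 2 to compound 3 (0.06 log units; within the scatter), so the bulk of that protected amine is not required to hold this level of binding. Placing 3-(hydroxymethyl)piperidin-1-yl in place of (aminomethyl)amino on a carbonyl carbon gives a 3.2-fold lower number from compound 1 to compound 3 (0.51 log units; beyond the scatter), a modest gain. No measurement available here explains either step. Still open, as far as these compounds go, is whether a free amine or a carboxylic acid on that saturated chain carbon would give a lower number. From the compounds shown here alone, a longer chain carrying the hydroxy group is equally open.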